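This account rests on a few compounds, and the source may have more. Where it says the series, first, only, none or still open, it means among the compounds named here.

Going by the values given here, in a functional assay on microsomes from liver (Rattus norvegicus, strain Wistar) for inhibition, with a stated time of 15 min (a higher number here means a weaker inhibitor, a lower number a stronger inhibitor), three compounds on a shared core have numbers so far: compound 1 `COc1cc(C2CC(c3cc4ccccc4o3)=NN2C(=O)Nc2ccccc2)ccc1O` gives 116000000 nM and compound 2 `COc1cc(C2CC(c3cc4ccccc4o3)=NN2C(=O)Nc2ccc(F)cc2)ccc1O` gives 125000000 nM in the same range. Compound 3 `COc1cc(NC(=O)N2N=C(c3cc4ccccc4o3)CC2c2ccc(O)c(OC)c2)ccc1O` gives 12000000 nM as the lowest of the three numbers, and its steps to both others lie beyond the scatter.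

Compound 4 `COc1cc(C2CC(c3cc4ccccc4o3)=NN2C(=O)Nc2ccc(Br)cc2)ccc1O` has not yet been measured. It departs from compound 3 by 4-bromophenyl in place of 4-hydroxy-3-methoxyphenyl on an amide-type nitrogen as its one structural difference: 4-bromophenyl in place of 4-hydroxy-3-methoxyphenyl on an amide-type nitrogen.

Among the compounds with values here, three measured steps bear on this change. The closest is a 10-fold lower number from compound 2 to compound 3 (1.02 log units; beyond the scatter) for the reverse kind of exchange, with 4-fluorophenyl leaving. The step of a 9.7-fold lower number from compound 1 to compound 3 (0.99 log units; beyond the scatter) is of similar size and starts from phenyl. Within the data shown here, the step of a 1.1-fold higher number from compound 1 to compound 2 (0.03 log units; within the scatter) shows that fluoro in place of hydrogen moved nothing measurable, although no bromo compound has a number yet.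

Losing the 4-hydroxy-3-methoxyphenyl group is therefore expected to undo most of that gain and return the number to the level of compound 1 and compound 2. The estimate is an 8.3-fold higher number from compound 3 to compound 4 (0.92 log units; beyond the scatter) as a step towards a weaker inhibitor, beyond the scatter. Compound 4 is expected at 100000000 nM within an estimated range of 35000000 nM to 250000000 nM in this assay.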

Compound 4, half-maximal inhibitory concentration: 115000000 nM
The estimate for compound 4 lay 1.2-fold (0.06 log units) below the measured number, within the range that was stated.
By their numbers in this assay, from the lowest: compound 3; then compounds 4, 1 and 2 (each within the scatter of the next).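

In this assay, bromo now joins fluoro as a second halogen that leaves the number where the unsubstituted phenyl compound stands: the steps are a 1.0-fold lower number from compound 1 to compound 4 (0.00 log units; within the scatter) and a 1.1-fold lower number from compound 2 to compound 4 (0.04 log units; within the scatter). With a 9.6-fold higher number from compound 3 to compound 4 (0.98 log units; beyond the scatter), a third exchange involving the 4-hydroxy-3-methoxyphenyl group gives a step beyond the scatter, so on this amide-type nitrogen the three compounds without that group form one level and compound 3 alone stands apart with the lowest number. Nothing shown here gives a reason for this separation.

Which part of the 4-hydroxy-3-methoxyphenyl group carries the difference stays open, as the hydroxy and methoxy groups appear only together, and a 4-hydroxyphenyl or a 3-methoxyphenyl group on the same nitrogen would separate the two. From the compounds shown here alone, it is equally open whether an amine or a carboxylic acid on the phenyl ring would stay at the level of compound 1 or move towards compound 3, and whether the same exchange would give a step of this size with the rest of the shared core changed.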